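Methyl for bromo on a thiazolyl hydrazone pair

The compounds below may be only part of what the source reports. "The series", "measured", "known", "first", "only" and "open" are said of these compounds alone.

Compound 1 `C/C(=N\Nc1nc(-c2ccc(Br)cc2)cs1)c1sc(C)nc1C` and compound 2 `C/C(=N\Nc1nc(-c2ccc(C)cc2)cs1)c1sc(C)nc1C` share one core, and compound 3 `C/C(=N\Nc1nc(-c2ccc(Br)cc2)cs1)c1sc(-c2ccccc2)nc1C` and compound 4 `C/C(=N\Nc1nc(-c2ccc(C)cc2)cs1)c1sc(-c2ccccc2)nc1C` share another; the two cores differ in that compound 3 carries phenyl in place of methyl on an aromatic carbon compared with compound 1. In a toxicity assay on THP-1 cells (Homo sapiens) for cytotoxicity, read by MTT assay (on this read-out higher numbers stand for weaker inhibition of growth and lower numbers for stronger inhibition of growth), compound 1 gives only a limit, > 100 ug/mL. Compound 2 likewise gives only a limit, > 100 ug/mL. Among the compounds with values here, compound 3 is the one member of the set with a number in this assay, where compound 3 gives 48.9 ug/mL. The change from compound 1 to compound 3, (phenyl in place of methyl on an aromatic carbon), thus reads as an at least 2.0-fold lower number from compound 1 to compound 3 (0.31 log units; beyond the scatter). The change from compound 1 to compound 2 is methyl in place of bromo on an aromatic carbon, and its step in this assay is a step that the two limits leave unreadable from compound 1 to compound 2; this is so because the limit of > 100 ug/mL in this assay, at which 2 of the 3 values shown sit, leaves both ends unreadable.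

Compound 4 differs from compound 3 by the same change, (methyl in place of bromo on an aromatic carbon). Since the measured pair gives no readable size for this change, the expectation for compound 4 rests mainly on the value of compound 3, 48.9 ug/mL, with the step from compound 3 to compound 4 in this assay expected to be a 1.4-fold higher number from compound 3 to compound 4 (0.16 log units; within the scatter). Compound 4 is therefore estimated to give about 70 ug/mL in this assay, with a plausible range from 35 ug/mL to 150 ug/mL.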

Compound 4, concentration for 50% growth inhibition: > 100 ug/mL
Compound 4 ended at the assay's limit (the forecaster's own chance of this, stated with the estimate: 30%); middle value at least 1.4-fold (0.15 log units) away from the limit.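

In this assay, methyl in place of bromo on the core of compound 3 gives an at least 2.0-fold higher number from compound 3 to compound 4 (0.31 log units; beyond the scatter), so on this core the 4-bromophenyl compound inhibits growth more strongly than the 4-methylphenyl compound. Compound 4 gives > 100 ug/mL, which is a limit of the assay and not a number, so the step has a least size but no known full size. Whether the change carries from one core to the other is not shown, because the same change on the core of compound 1 cannot be read, and neither can the step from compound 2 to compound 4: the limit of > 100 ug/mL in this assay, at which 3 of the 4 values shown sit.

All the compounds shown carry either 4-bromophenyl or 4-methylphenyl, so it stays open how an amine, a carboxylic acid or a longer chain in that place would read in this assay. Within the data shown here, with only one number among the four compounds, it also stays open how large the step from bromo to methyl is on either core, and whether its size on the core of compound 3 would hold on the core of compound 1.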